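Two chlorines on the phenyl of compound 1

The compounds below may be only part of what the source reports. "The series", "measured", "known", "first", "only" and "open" are said of these compounds alone.

Measured in a functional assay on HCT-15 cells (Homo sapiens) for inhibition, read by sulforhodamine B assay, with a stated time of 48 h (a higher number here means a weaker inhibitor of growth, a lower number a stronger inhibitor of growth), so far:
Compound 1 `O=C(Cc1csc2nc(-c3ccc(Br)cc3)cn12)N/N=C/c1ccccc1` gives 16200 nM
Compound 2 `O=C(Cc1csc2nc(-c3ccc(Br)cc3)cn12)N/N=C/c1ccccc1O` gives 955 nM

Of this pair, compound 1 has the higher number (16200 nM), which makes it the weaker inhibitor of growth. Compound 3 (`O=C(Cc1csc2nc(-c3ccc(Br)cc3)cn12)N/N=C/c1ccc(Cl)cc1Cl`) has not been measured yet. It keeps the core of compound 1 and exchanges one group (2,4-dichlorophenyl in place of phenyl on a carbon with a double bond to nitrogen). For the measured compounds named here, only one measured step bears on this change, and only indirectly: a 17-fold lower number from compound 1 to compound 2 (1.23 log units; beyond the scatter), where hydroxy took the place of hydrogen on an aromatic carbon. That large step shows that a change on this ring can move the number a long way. Hydroxy is not chlorine, however, and no compound with chlorine has been measured, so the size of the step cannot simply be carried over. The expected step in this assay is a 3.2-fold lower number from compound 1 to compound 3 (0.51 log units; beyond the scatter), in the same direction as the hydroxy step but smaller, and the uncertainty is wide. For compound 3 the estimated value is 5000 nM (expected range 1200 nM to 20000 nM).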

Compound 3, concentration for 50% growth inhibition: 25700 nM
The estimate for compound 3 lay 5.1-fold (0.71 log units) below the measured number; measured number outside the range, above it.
By their numbers in this assay, from the lowest: compound 2; then compounds 1 and 3 (each within the scatter of the next).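

In this assay, 2,4-dichlorophenyl in place of phenyl on a carbon with a double bond to nitrogen gives a 1.6-fold higher number from compound 1 to compound 3 (0.20 log units; within the scatter), so compound 1 and compound 3 cannot be told apart here, even though the ring now carries two chlorines. Set against the hydroxy compound, 2,4-dichlorophenyl in place of 2-hydroxyphenyl gives a 27-fold higher number from compound 2 to compound 3 (1.43 log units; beyond the scatter), which shows that the large step to compound 2 does not appear with every substitution on this ring. Among these three compounds, only compound 2 stands apart from the others, and no measurement shown here explains the difference between the hydroxy group and the two chlorines.

Going by these compounds, the two chlorines enter together in compound 3, so the effect of a single chlorine on this ring remains unknown, and two chlorines giving no clear change do not settle what each one does alone. On these data alone, it also remains open whether the low number of compound 2 would survive with a methoxy group or an amine in place of the hydroxy group, which would show how particular that group is at this position.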